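This account rests on a few compounds, and the source may have more. Where it says the series, first, only, none or still open, it means among the compounds named here.

Series notes. Compound 2 `Cc1cc(C)n2nc(SCc3cc(=O)c4cc(Cl)ccc4o3)nc2n1` is known in a functional assay on HeLa cells (Homo sapiens) for cytotoxicity, read by MTT assay, with a stated time of 72 h (a higher number here means a weaker inhibitor, a lower number a stronger inhibitor), only as a limit: compound 2 gives > 25000 nM. Compound 1 `Cc1ccc2oc(CSc3nc4nc(C)cc(C)n4n3)cc(=O)c2c1` likewise returns a limit in this assay, namely > 25000 nM. Compound 3 `Nc1nc(SCc2coc3ccccc3c2=O)n[nH]1` also returns a limit in this assay, namely > 25000 nM. Among the measured compounds shown here, the single measured step, a step that the two limits leave unreadable from compound 1 to compound 2, cannot be read because of the limit of > 25000 nM in this assay, at which 3 of the 3 values shown sit. Compound 4 `Cc1cc(C)n2nc(SCc3cc(=O)c4ccccc4o3)nc2n1` differs from compound 2 by hydrogen in place of chloro on an aromatic carbon. For the measured compounds named here, no measured step bears directly on this change, and every value seen so far is a limit, so no step beyond the scatter is expected in this assay. Compound 4 is therefore expected to give 40000 nM (range 15000 nM to 150000 nM), most likely again reported as a limit. The step that the limit leaves unreadable from compound 2 to compound 4 is accordingly estimated as essentially none.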

Compound 4, half-maximal inhibitory concentration: > 25000 nM
Compound 4 was reported as a limit; the forecaster's own chance of this, stated with the estimate: 85%; the middle value lies beyond the limit too.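

No new step can be read among compound 1, compound 2 and compound 4, each known only as a limit: the limit of > 25000 nM in this assay, at which 4 of the 4 values shown sit.
In this assay the compounds shown leave open how chloro, methyl or hydrogen on this aromatic carbon compare.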